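This account rests on a few compounds, and the source may have more. Where it says the series, first, only, none or still open, it means among the compounds named here.

Measured compounds:
Compound 1, `CNc1nc(C)c(C(=O)N/N=C/c2ccc(C(F)(F)F)cc2)s1`: > 100 ug/mL
Compound 2, `CN(C(=O)NC(=O)c1ccccc1F)c1nc(C(F)(F)F)c(C(=O)N/N=C/c2ccc(C(F)(F)F)cc2)s1`: 4.56 ug/mL

For the measured compounds named here, in a functional assay on HepG2 cells (Homo sapiens) for inhibition, read by MTT assay, with a stated time of 72 h (a higher number here means a weaker inhibitor, a lower number a stronger inhibitor), compound 2 gives 4.56 ug/mL, the only number on hand in this assay. Going by the values given here, the value of compound 1 in this assay is a limit, > 100 ug/mL, and not a number, so compound 2 stands alone as the one compound with a measured potency.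

Compound 3, `CNc1nc(C(F)(F)F)c(C(=O)N/N=C/c2ccc(C(F)(F)F)cc2)s1`, has not been measured in this assay. It differs from compound 2 in one place: hydrogen in place of ((2-fluorophenyl)carbonyl)carbamoyl on a nitrogen on an aromatic ring. Among the compounds with values here, no measured pair shows this change directly. Compound 1, which also carries hydrogen on that nitrogen, reaches only (the limit of > 100 ug/mL in this assay, at which 1 of the 2 values shown sits), and compound 3 shares that feature with it, so a loss of potency beyond the scatter is expected on removing the group.

Compound 3 is therefore estimated to come in at 60 ug/mL, within 10 ug/mL to 150 ug/mL, a step of a 13-fold higher number from compound 2 to compound 3 (1.12 log units; beyond the scatter) that is expected to be a clear weakening, with a real chance that only a limit is reported.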

Compound 3, half-maximal inhibitory concentration: > 100 ug/mL
Compound 3: only a limit was reported (the forecaster's own chance of this, stated with the estimate: 55%); middle value at least 1.6-fold (0.22 log units) from the limit.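

In this assay, replacing the ((2-fluorophenyl)carbonyl)carbamoyl group on the nitrogen on the aromatic ring with hydrogen produces a large loss of potency (an at least 21-fold higher number from compound 2 to compound 3 (1.34 log units; beyond the scatter)), so this change is now seen directly in a single pair rather than inferred from a shared feature. Trifluoromethyl stays on the aromatic carbon in both compound 2 and compound 3, which shows that this group alone does not preserve a measurable potency once the nitrogen carries hydrogen. The step between compound 1 and compound 3 cannot be read, as each of the two compounds has only a limit, and both compounds with hydrogen on that nitrogen now share the same limit: the limit of > 100 ug/mL in this assay, at which 2 of the 3 values shown sit.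

On these data alone, it remains open whether the potency of compound 2 requires the whole ((2-fluorophenyl)carbonyl)carbamoyl group or only part of it, as a simple acetyl group or an unsubstituted benzoyl urea on that nitrogen would show. Also open, as far as these compounds go, is how much the trifluoromethyl contributes when that group is present, which a methyl on the aromatic carbon in its place would test.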